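Methoxy on the benzyl ring of compound 2

This account rests on a few compounds, and the source may have more. Where it says the series, first, only, none or still open, it means among the compounds named here.

Compound 1 `Cc1ccccc1Nc1ncnn1-c1cccc(Cl)c1Cl` gives 17.8 nM in a functional assay for antagonist activity at P2X purinoceptor 7 (Homo sapiens), read by FLIPR and calcium flux; a higher number here means a weaker inhibitor, a lower number a stronger inhibitor. Among the measured compounds shown here, compound 2 `Clc1cccc(-n2ncnc2NCc2ccccc2)c1Cl` gives 47.9 nM in this assay, the higher of the two numbers measured so far, reached by a 2.7-fold higher number from compound 1 to compound 2 (0.43 log units; beyond the scatter). Compound 3 `COc1cccc(CNc2ncnn2-c2cccc(Cl)c2Cl)c1` carries methoxy in place of hydrogen on an aromatic carbon. For the measured compounds named here, no measured step touches that ring: the only step recorded, a 2.7-fold higher number from compound 1 to compound 2 (0.43 log units; beyond the scatter), exchanges the whole group on the ring nitrogen and was modest, so it offers no direct guide. Without precedent, the expectation for compound 3 is a step of a 1.1-fold lower number from compound 2 to compound 3 (0.03 log units; within the scatter) in this assay, not beyond the scatter. The estimate for compound 3 is 45 nM in this assay, with a range from 15 nM to 130 nM.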

Compound 3, half-maximal inhibitory concentration: 288 nM
The estimate for compound 3 lay 6.4-fold (0.81 log units) below the measured number; the whole stated range lies below it.
By their numbers in this assay, from the lowest: compound 1; then compound 2; then compound 3.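

In this assay methoxy on an aromatic carbon of the benzyl ring, meta to a large group, gives a 6.0-fold higher number from compound 2 to compound 3 (0.78 log units; beyond the scatter) and so shows that this ring position is not indifferent to substitution. A group of only 2 heavy atoms is enough for a step beyond the scatter. Nothing measured here accounts for this step. As far as these compounds go, whether the rise belongs to methoxy itself or to any group at this carbon stays open; fluorine or hydroxyl there would separate the two readings. From the compounds shown here alone, how methoxy behaves on the other carbons of the ring also stays open.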